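Isopropyl in place of hydroxymethyl on compound 3

A few compounds are considered here, and "the series" means these few. Any claim that something is new, unique, unknown or untested is made for them only; others in the source may bear on it.

In a physicochemical assay for lipophilicity, read by HPLC, at pH 7.5 (a higher number here means a more lipophilic compound, a lower number a more polar compound), compound 3 `CC[C@@H](Nc1c(C#N)c(-c2ccc(-c3ccccc3CO)cc2)nc2cnccc12)C(N)=O` gives 2.1. Compound 2 `CC[C@@H](Nc1c(C#N)c(-c2ccc(Br)cc2)nc2cnccc12)C(N)=O` gives 2.2, which leaves the two level, as a number 0.10 log units lower from compound 2 to compound 3 (within the scatter) shows. Compound 1 `CC[C@@H](Nc1c(C#N)c(-c2ccc(-c3ccc(Cl)cc3)cc2)nc2cnccc12)C(N)=O` gives 3.1, clearly above both.

The next structure is compound 4 `CC[C@@H](Nc1c(C#N)c(-c2ccc(-c3ccccc3C(C)C)cc2)nc2cnccc12)C(N)=O`, with isopropyl in place of hydroxymethyl on an aromatic carbon, ortho to a large group: isopropyl in place of hydroxymethyl on an aromatic carbon. The same difference reads 2-(hydroxymethyl)phenyl to 2-isopropylphenyl.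

Going by the values given here, no measured step exchanges these two groups directly, and no measured compound carries isopropyl. The nearest evidence is a number 1.00 log units lower from compound 1 to compound 3 (beyond the scatter), where 2-(hydroxymethyl)phenyl stands in place of 4-chlorophenyl. A step of similar size appears in a number 0.90 log units lower from compound 1 to compound 2 (beyond the scatter). A modest rise in this assay is therefore expected, and the expected step is a number 1.10 log units higher from compound 3 to compound 4 (beyond the scatter). This would bring the value back to about the level of compound 1, though that remains an expectation resting on a single comparable step.

The estimate for compound 4 is 3.2, with an expected range of 2.8 to 3.7.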

Compound 4, distribution coefficient: 3.5
The estimate for compound 4 lay 0.30 log units below the measured number, and the stated range covers the measured number.
By their numbers in this assay, from the lowest: compounds 3 and 2 (each within the scatter of the next); then compound 1; then compound 4.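

In this assay, going by these compounds alone, the swap on this aromatic carbon, ortho to a large group, gives the first large step, a number 1.40 log units higher from compound 3 to compound 4 (beyond the scatter), as hydroxymethyl, with its hydrogen-bond donor and acceptor, gives way to isopropyl, which has neither. The 2-isopropylphenyl group also separates clearly from both other substituents, with a number 1.30 log units higher from compound 2 to compound 4 (beyond the scatter) and a number 0.40 log units higher from compound 1 to compound 4 (beyond the scatter), making compound 4 the highest of the four and showing that 4-chlorophenyl did not mark the top of the range at this position. Nothing measured here bears on what sets the size of these steps.

Open, as far as these compounds go, is how this assay reads for a methoxymethyl or aminomethyl group on the same carbon. Also open, from the compounds shown here alone, is whether a step of this size holds for isopropyl elsewhere on that ring.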